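A few compounds are considered here, and "the series" means these few. Any claim that something is new, unique, unknown or untested is made for them only; others in the source may bear on it.

Compound 2 `Cc1cccc(NC(=O)CN2CCC(c3ccc(O)cc3)CC2)c1` is the lower of the two measured compounds. In a functional assay on HEK293 cells for agonist activity at D(4) dopamine receptor (Homo sapiens), read by FLIPR (on this read-out higher numbers stand for larger maximal responses and lower numbers for smaller maximal responses), compound 2 gives 60%, whereas compound 1 `Cc1cc(NC(=O)CN2CCC(c3cccc[n+]3[O-])CC2)ccc1F` gives 75%, a gap that lies beyond the usual scatter. Compound 3 `Cc1cccc(NC(=O)CN2CCC(c3ccc(O)cn3)CC2)c1` is the unmeasured neighbour of compound 2; it carries 5-hydroxypyridin-2-yl in place of 4-hydroxyphenyl on a saturated ring carbon. Among the compounds with values here, no measured pair in this set shows such a change, so the step from compound 2 to compound 3 is expected to be small, perhaps slightly upward, and likely within the scatter, namely a number 5 percentage points higher from compound 2 to compound 3 (within the scatter). Compound 3 is therefore estimated at 65%, with a range from 45% to 85%.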

Compound 3, largest response reached (reported as efficacy), in percent of the reference or control that the assay uses: 83%
Beside the measured number, compound 3's estimate is 18 percentage points below it; the measured number falls inside the stated range.
By their numbers in this assay, from the lowest: compound 2; then compounds 1 and 3 (each within the scatter of the next).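

In this assay, within the data shown here, 5-hydroxypyridin-2-yl in place of 4-hydroxyphenyl on a saturated ring carbon gives a number 23 percentage points higher from compound 2 to compound 3 (beyond the scatter), the first step that can be read at this position. It shows that the maximal response is sensitive to the ring at this carbon, even with the rest of the molecule unchanged. Nothing available explains this step. The compounds shown leave open whether the hydroxyl is needed on the pyridine ring, and what a 5-methoxypyridin-2-yl or 5-aminopyridin-2-yl group would give at this carbon.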